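Compound 3 to compound 4: methyl replaced by ethoxy

This account rests on a few compounds, and the source may have more. Where it says the series, first, only, none or still open, it means among the compounds named here.

- compound 1 `Cc1ccccc1-c1cc(C(=O)N2CCC3(CC2)CC(=O)c2nn(C(C)(C)C)cc2O3)c2ccccc2n1`: 1880 nM
- compound 2 `CC(C)(C)n1cc2c(n1)C(=O)CC1(CCN(C(=O)c3cc(-c4ccncc4)nc4ccccc34)CC1)O2`: 550 nM
- compound 3 `Cc1cc(C(=O)N2CCC3(CC2)CC(=O)c2nn(C(C)(C)C)cc2O3)c2ccccc2n1`: > 10000 nM

All three values come from a functional assay on A549 cells (Homo sapiens) for inhibition, read by MTT assay, with a stated time of 72 h; a lower number here means a stronger inhibitor, a higher number a weaker inhibitor. Compound 3 has no number, only a limit of the assay (> 10000 nM). Its standing in the series therefore rests on (the limit of > 10000 nM in this assay, at which 1 of the 3 values shown sits).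

Compound 4 `CCOc1cc(C(=O)N2CCC3(CC2)CC(=O)c2nn(C(C)(C)C)cc2O3)c2ccccc2n1` differs from compound 3 at one place: ethoxy in place of methyl on an aromatic carbon. This is ethoxy in place of methyl on an aromatic carbon, next to the ring nitrogen.

No ethoxy has been measured on this carbon. Going by the values given here, the steps that bear on it are the replacement of 2-methylphenyl by methyl (an at least 5.3-fold higher number from compound 1 to compound 3 (0.72 log units; beyond the scatter)) and of pyridin-4-yl by methyl (an at least 18-fold higher number from compound 2 to compound 3 (1.25 log units; beyond the scatter)). Both are beyond the scatter, and the second is large. The exchange of the two ring groups (a 3.4-fold lower number from compound 1 to compound 2 (0.53 log units; beyond the scatter)) shows that the substituent on this carbon matters.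

Ethoxy brings no ring, so compound 4 is expected to sit nearer compound 3 than compound 1. A small move toward a lower number is expected, with the estimated step being an at least 1.4-fold lower number from compound 3 to compound 4 (0.15 log units; that floor lies within the scatter). Compound 4 is estimated at 7000 nM (expected range 2500 nM to 20000 nM).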

Compound 4, half-maximal inhibitory concentration: > 10000 nM
Compound 4: only a limit was reported; the forecaster's own chance of this, stated with the estimate: 45%; middle value at least 1.4-fold (0.15 log units) from the limit.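

In this assay compound 4 gives only a limit of the assay, > 10000 nM, so ethoxy on this carbon, next to the ring nitrogen, does not yield a numerical value any more than methyl does. The two ring-bearing groups stay clearly ahead of ethoxy, with an at least 18-fold higher number from compound 2 to compound 4 (1.25 log units; beyond the scatter) and an at least 5.3-fold higher number from compound 1 to compound 4 (0.72 log units; beyond the scatter), and among the four compounds only those with a ring on this carbon give a number. Compound 3 and compound 4 both stand at a limit, so the steps between them cannot be read: the limit of > 10000 nM in this assay, at which 2 of the 4 values shown sit.

Going by these compounds, whether ethoxy differs from methyl at all remains unknown, since any difference lies beyond the reach of these limits. Also open, on these data alone, is whether an amine or a longer chain on this carbon would give a number, or whether a saturated ring such as morpholine would match the aromatic rings of compound 1 and compound 2.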